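Compound 3 to compound 4: fluoro replaced by 5-methylfuran-2-yl

The source may hold more compounds than are shown below. What is called first, only, known or untested is meant among the compounds shown, and "the series" means these compounds.

Compound 1 `CON(C)C(=O)C1(S(=O)(=O)c2ccc(Oc3ccc(OC(F)(F)F)cc3)cc2)CCC2(CCNCC2)C1`: 3700 nM
Compound 2 `COC(=O)C1(S(=O)(=O)c2ccc(Oc3ccc(OC(F)(F)F)cc3)cc2)CCC2(CCNCC2)C1`: > 15000 nM
Compound 3 `Nc1ccc(F)cc1NC(=O)C1(S(=O)(=O)c2ccc(Oc3ccc(OC(F)(F)F)cc3)cc2)CCC2(CCNCC2)C1`: > 15000 nM

The measurements come from a functional assay on blood (Homo sapiens), with a stated time of 60 min, in the presence of a further agent that is not named here; a lower number here means that less compound is needed, a higher number that more compound is needed for the effect. Only compound 1 has a true number. The value of compound 2 is a limit. On these data alone, compound 3 gives > 15000 nM, also a limit and not a number, so its true position is unknown.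

Compound 4 `Cc1ccc(-c2ccc(N)c(NC(=O)C3(S(=O)(=O)c4ccc(Oc5ccc(OC(F)(F)F)cc5)cc4)CCC4(CCNCC4)C3)c2)o1` has 5-methylfuran-2-yl in place of fluoro on an aromatic carbon, para to an amino group and meta to a large group: 5-methylfuran-2-yl in place of fluoro on an aromatic carbon.

The measured steps all concern the group on the carbonyl carbon: an at least 4.0-fold higher number from compound 1 to compound 2 (0.60 log units; beyond the scatter), an at least 4.0-fold higher number from compound 1 to compound 3 (0.60 log units; beyond the scatter) and a step that the two limits leave unreadable from compound 2 to compound 3. None of them changes this aromatic carbon, so they give no size for the new step. For the measured compounds named here, the size of the first two shows only that compound 3 lost ground against compound 1.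

With no measured support for a shift, a number no higher from compound 3 to compound 4 (the limit leaves the size open) is the expected step, and it is only weakly founded. For compound 4 the estimated value is 15000 nM, with an expected range of 4000 nM to 45000 nM.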

Compound 4, half-maximal effective concentration: > 15000 nM
Compound 4 was reported as a limit; the forecaster's own chance of this, stated with the estimate: 70%; the middle value sits exactly at the limit.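

Compound 3 and compound 4 both stand only as limits in this assay, so no step between them can be read: the limit of > 15000 nM in this assay, at which 3 of the 4 values shown sit.

The compounds shown leave open whether 5-methylfuran-2-yl in place of fluoro shifts the half-maximal effective concentration at all.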